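This account rests on a few compounds, and the source may have more. Where it says the series, first, only, none or still open, it means among the compounds named here.

Measured so far in a functional assay on MGC-803 cells (Homo sapiens) for antiproliferative activity, read by CCK-8 assay, with a stated time of 72 h, tested at 2 uM; on this read-out lower numbers stand for a weaker effect and higher numbers for a stronger effect at the one concentration tested:
Compound 1 `Nc1ccccc1NC(=O)c1ccc(CSC(=S)N2CCN(c3ccc(Cl)cc3)CC2)cc1` gives 15%.
Compound 2 `Nc1ccccc1NC(=O)c1ccc(CSC(=S)N2CCc3cc(Cl)ccc32)cc1` gives 57.7%.
Compound 3 `CC1CCN(C(=S)SCc2ccc(C(=O)Nc3ccccc3N)cc2)CC1` gives 28.1%.

All three share one core and differ only in the group attached to the thiocarbonyl carbon. Compound 1 stands lowest of the three; compound 3 lies well above it, and compound 2 lies highest. For the measured compounds named here, the one single-point step measured so far, a number 29.6 percentage points lower from compound 2 to compound 3 (beyond the scatter), concerns the swap of 5-chloro-2,3-dihydro-1H-indol-1-yl for 4-methylpiperidin-1-yl on the thiocarbonyl carbon.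

Compound 4 `Nc1ccccc1NC(=O)c1ccc(CSC(=S)N2CCN(c3ccccc3F)CC2)cc1` has not been measured. It differs from compound 1 in one place: 2-fluorophenyl in place of 4-chlorophenyl on an amine nitrogen in a ring. Here the whole group on the thiocarbonyl carbon is kept and only the aromatic ring on the amine nitrogen in the ring is exchanged, 2-fluorophenyl for 4-chlorophenyl. Going by the values given here, no measured step touches this kind of change: the step from compound 2 to compound 3 replaces the entire group on the thiocarbonyl carbon, so it gives no guide to exchanging one halogen-bearing ring for another. The expected step is therefore a number 3 percentage points higher from compound 1 to compound 4 (within the scatter), which is none beyond the scatter. Compound 4 is estimated at 18%, with a range from 5% to 40%.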

Compound 4, a percentage reported as inhibition, at one concentration (the size of the read-out at that concentration, not a potency): 33.7%
Compound 4: the middle estimate sits 15.7 percentage points below what was measured; low and high end bracket the measured number.
By their numbers in this assay, from the lowest: compound 1; then compounds 3 and 4 (each within the scatter of the next); then compound 2.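

In this assay, exchanging 4-chlorophenyl for 2-fluorophenyl on the amine nitrogen in the ring gives a number 18.7 percentage points higher from compound 1 to compound 4 (beyond the scatter), so this ring can change the read-out even when the rest of the group on the thiocarbonyl carbon stays the same. The earlier step replaced that entire group, whereas this one is a far smaller edit: both rings have the same number of heavy atoms, neither has hydrogen-bond donors or acceptors, and neither carries a net charge, so these counts do not separate them. No measured information is available to explain the rise.

The exchange alters both the halogen and its place on the ring, and the compounds shown cannot tell which of the two matters, or whether both do. They also leave open how this position would respond to a plain phenyl ring, or to a phenyl ring carrying a methoxy group or an amine, and whether any such ring could bring this series close to compound 2 at 57.7%.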